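What a side-chain swap may do to clearance

The compounds below may be only part of what the source reports. "The series", "measured", "known", "first", "only" and "open" are said of these compounds alone.

In an ADME assay on liver for metabolic stability, with Liver microsome (Homo sapiens) as the target, using microsomes and NADPH, with a stated time of 30 min, tested at 0.5 uM (a higher number here means faster removal of the compound, a lower number slower removal), compound 1 `O=C1NCCN1CCOc1nn(-c2ccccc2F)c2ccc(F)cc12` gives 183 mL/min/kg and compound 2 `Fc1ccc2c(c1)c(OCCn1ccnc1)nn2-c1ccccc1F` gives 150 mL/min/kg. Among the compounds with values here, these two numbers lie within the scatter of each other, so compound 2 cannot be told apart from the only other compound measured. Compound 3 `O=C(COc1nn(-c2ccccc2F)c2ccc(F)cc12)N1CCOCC1` keeps the shared core and changes the side chain: (morpholin-4-yl)carbonyl in place of (1H-imidazol-1-yl)methyl on a saturated chain carbon bound to an oxygen on an aromatic ring. In short, (morpholin-4-yl)carbonyl takes the place of (1H-imidazol-1-yl)methyl. Within the data shown here, only one measured step bears on this, and it is a small one: a 1.2-fold lower number from compound 1 to compound 2 (0.09 log units; within the scatter). Among the measured compounds shown here, that step swapped a different group on the same chain, and no measured compound carries a morpholine ring, so it is a weak guide. With so little evidence, no change beyond the scatter is expected, and the expected step is a 1.2-fold lower number from compound 2 to compound 3 (0.06 log units; within the scatter). For compound 3 the estimate is 130 mL/min/kg, with an expected range of 65 mL/min/kg to 220 mL/min/kg.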

Compound 3, clearance: 117 mL/min/kg
The estimate for compound 3 lay 1.1-fold (0.05 log units) above the measured number, within the range that was stated.
By their numbers in this assay, from the lowest: compounds 3, 2 and 1 (each within the scatter of the next).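

In this assay the swap to (morpholin-4-yl)carbonyl from (1H-imidazol-1-yl)methyl gives a small step (a 1.3-fold lower number from compound 2 to compound 3 (0.11 log units; within the scatter)), and the swap from (2-oxoimidazolidin-1-yl)methyl gives another (a 1.6-fold lower number from compound 1 to compound 3 (0.19 log units; within the scatter)). On this saturated chain carbon, then, a six-membered non-aromatic ring joined through a carbonyl can take the place of either earlier group without a step that rises above the scatter, so the three side chains cannot be told apart here. Nothing available explains why these numbers stay so close.

As far as these compounds go, it remains open whether a simple amine, a carboxylic acid or a longer chain in this place would give a step beyond the scatter. From the compounds shown here alone, all three compounds also share one core, so what a change to either fluorine would do is unknown.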